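Phenytoin-derived aminomethyl series: a smaller group on the ring nitrogen

A few compounds are considered here, and "the series" means these few. Any claim that something is new, unique, unknown or untested is made for them only; others in the source may bear on it.

Two members of the series have been measured in a functional assay on the whole organism (strain CD1) with Mus musculus as the target, in the maximal electroshock model, with a stated time of 4 h; on this read-out lower numbers stand for an effect already at smaller amounts and higher numbers for an effect only at larger amounts of compound. Compound 1 `O=C1NC(c2ccccc2)(c2ccccc2)C(=O)N1CN1CCN(c2cccc(Cl)c2)CC1` gives 100 mg/kg. Compound 2 `O=C1NC(c2ccccc2)(c2ccccc2)C(=O)N1CN1CCN(c2ccccc2F)CC1` gives 30 mg/kg. Among the compounds with values here, the one step between them, a 3.3-fold lower number from compound 1 to compound 2 (0.52 log units; beyond the scatter), exchanges one aromatic ring for another on the same ring nitrogen. On these two numbers compound 2 stands lowest, with compound 1 the only other point and higher beyond the scatter.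

Compound 3 `CN1CCN(CN2C(=O)NC(c3ccccc3)(c3ccccc3)C2=O)CC1` is not yet measured. Its difference from compound 2 is methyl in place of 2-fluorophenyl on an amine nitrogen in a ring. Within the data shown here, no measured step covers this kind of change: the single step known swaps one aromatic ring for another, whereas here an aromatic ring is removed and a methyl remains. That step therefore gives no direction for the expected size in this assay, and the estimate must be wide.

Compound 3 is expected to give 100 mg/kg in this assay, with a range of 30 mg/kg to 300 mg/kg. The estimated step of a 3.3-fold higher number from compound 2 to compound 3 (0.52 log units; beyond the scatter) thus leans toward a higher number, with considerable chance that only a limit is reported.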

Compound 3, minimum effective dose: 10 mg/kg
Compound 3: the middle estimate sits 10-fold (1.00 log units) above what was measured; the measured number lies below the stated range.
By their numbers in this assay, from the lowest: compound 3; then compound 2; then compound 1.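

In this assay, the group on this amine nitrogen does not need an aromatic ring: methyl in place of 2-fluorophenyl gives a 3.0-fold lower number from compound 2 to compound 3 (0.48 log units; beyond the scatter), and methyl in place of 3-chlorophenyl gives a 10-fold lower number from compound 1 to compound 3 (1.00 log units; beyond the scatter). The earlier pair showed this position only with one aromatic ring exchanged for another, whereas compound 3 now shows that the single carbon of methyl, replacing the seven heavy atoms of 2-fluorophenyl, gives the lowest number of the three compounds. No supporting information is available to explain the direction or size of this change.

With only methyl and two halogen-bearing phenyl groups shown at this nitrogen, it remains open whether the number continues to fall with a bare hydrogen there or rises again with ethyl, propyl or a longer chain. Also open, on these data alone, is whether an unsubstituted phenyl or a benzyl group would stand closer to compound 2 or to compound 3, so the three numbers do not yet establish a trend with group size.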